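Swapping the 3-fluorophenyl group on a shared core

The source may report more compounds than this note shows. Statements on the series, on what has been measured and on what is new or still open speak of the compounds shown alone.

Compound 3 `COc1nc(-c2cccc(F)c2)ccc1[C@@H](c1ccccc1)[C@@](O)(CCN(C)C)c1cccc2ccccc12` gives 62.8 ug/mL in a toxicity assay on HeLa cells (Homo sapiens) for cytotoxicity (on this read-out higher numbers stand for lower toxicity in this test and lower numbers for higher toxicity in this test), the higher of the two numbers in this set. Among the compounds with values here, its nearest neighbour is compound 1 `COc1nc(C2CCOCC2)ccc1[C@@H](c1ccccc1)[C@@](O)(CCN(C)C)c1cccc2ccccc12`, which in this assay gives 22.5 ug/mL; the single step between them, a 2.8-fold higher number from compound 1 to compound 3 (0.45 log units; beyond the scatter), lies beyond the scatter. For compound 2 `COc1nc(-c2cccc(Cl)c2)ccc1[C@@H](c1ccccc1)[C@@](O)(CCN(C)C)c1cccc2ccccc12` this assay shows "nd" (no result reported), so no number can be set beside it. Compound 4 `COc1nc(-c2cnsc2)ccc1[C@@H](c1ccccc1)[C@@](O)(CCN(C)C)c1cccc2ccccc12` has not yet been measured. It differs from compound 3 in one place: 1,2-thiazol-4-yl in place of 3-fluorophenyl on an aromatic carbon. Within the data shown here, the only step that bears on this change, a 2.8-fold higher number from compound 1 to compound 3 (0.45 log units; beyond the scatter), concerns the same position but a different pair of groups, so it gives direction only loosely. Because compound 1 gives 22.5 ug/mL with a non-benzenoid group at this position, compound 4 is expected to move part of the way back, a 1.8-fold lower number from compound 3 to compound 4 (0.25 log units; within the scatter). Compound 4 is therefore estimated at 35 ug/mL, with a range from 12 ug/mL to 90 ug/mL.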

Compound 4, half-maximal cytotoxic concentration: 28.8 ug/mL
Compound 4: the middle estimate sits 1.2-fold (0.08 log units) above what was measured; low and high end bracket the measured number.
By their numbers in this assay, from the lowest: compounds 1 and 4 (each within the scatter of the next); then compound 3.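

In this assay the change from 3-fluorophenyl to 1,2-thiazol-4-yl gives a 2.2-fold lower number from compound 3 to compound 4 (0.34 log units; beyond the scatter), so an aromatic ring at this position does not by itself carry the number of compound 3. The other new step, a 1.3-fold higher number from compound 1 to compound 4 (0.11 log units; within the scatter), shows that the 1,2-thiazol-4-yl and oxan-4-yl groups cannot be told apart in this test, which leaves compound 3 alone at the less toxic end of the three numbered compounds. Nothing available explains why these groups read as they do.

As far as these compounds go, with no number for compound 2, it stays open whether chlorine in place of the fluorine on the phenyl ring would keep the reading of compound 3. The compounds shown also leave open how an unsubstituted phenyl ring, an amine or a carboxylic acid at this position would read.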